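A few compounds are considered here, and "the series" means these few. Any claim that something is new, unique, unknown or untested is made for them only; others in the source may bear on it.

Two compounds built on a shared core, each carrying a halogenated benzene ring, have been measured in a functional assay on HEp-2 cells (Homo sapiens) for cytotoxicity, read by MTT assay, with a stated time of 72 h, tested at 10 ug/mL; a higher number here means more inhibition of growth at the concentration tested, a lower number less inhibition of growth. Compound 1 `O=C1NC(=S)/C(=C/c2ccc(Cl)cc2)S1` gives 22.3% in this assay. Compound 2 `O=C1NC(=S)/C(=C/c2ccccc2Br)S1` gives 21.2% in this assay. Compound 1 thus holds the higher of the two numbers, but the gap to compound 2 lies within the usual scatter of such measurements, so the two values are best read as the same level of growth inhibition. Among the compounds with values here, compound 2 differs from compound 1 in more than one place, so no single structural step can be drawn between them.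

Compound 3 `O=C1NC(=S)/C(=C/c2ccc(Cl)c(Cl)c2)S1` has not yet been measured in this assay. It differs from compound 1 by one change: chloro in place of hydrogen on an aromatic carbon. Since both measured compounds, with different halogens in different places on the ring, land at a similar level, the added chloro group is expected to move the number only a little, if at all. The step from compound 1 to compound 3 is estimated at a number 2.7 percentage points higher from compound 1 to compound 3 (within the scatter), not beyond the scatter. Compound 3 is therefore expected to give about 25% in this assay, with a plausible range from 10% to 42%.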

Compound 3, percent growth inhibition at one concentration: 16.4%
Compound 3: middle estimate off by 8.6 percentage points, on the high side; the measured number falls inside the stated range.
By their numbers in this assay, from the lowest: compounds 3, 2 and 1 (each within the scatter of the next).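

Within the data shown here, the change from compound 1 to compound 3 is the first comparison here that differs in only one place, so it isolates a single substitution, which compounds 1 and 2 could not do. In this assay, chloro in place of hydrogen on an aromatic carbon, ortho to a chloro group and meta to a group of 8 heavy atoms, gives a number 5.9 percentage points lower from compound 1 to compound 3 (within the scatter). This position on the ring can therefore carry a second chloro group with no change that can be told apart from the ordinary spread of repeated measurements, and no measured information here bears on what lies behind this result.

The compounds shown leave open whether a different kind of group at this same position, such as an amine, a carboxylic acid or a longer carbon chain, would shift the number beyond that spread. Among these compounds, they also leave open what the chloro group already present in compound 1 contributes, since no compound here has a benzene ring that carries no halogen, and a comparison with such a compound would show this directly.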